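Replacing ethyl with 4-bromo-2-fluorophenyl on an amide-type nitrogen

The source may report more compounds than this note shows. Statements on the series, on what has been measured and on what is new or still open speak of the compounds shown alone.

In a functional assay on HUVEC cells (Homo sapiens) for antiproliferative activity, read by sulforhodamine B assay, with a stated time of 48 h (on this read-out lower numbers stand for stronger inhibition and higher numbers for weaker inhibition), compound 2 `CCNC(=O)Nc1ccc(Nc2ncnc3cc(OCC4CCN(C)CC4)ccc23)cc1` gives 587 nM, the higher of the two numbers available. Going by the values given here, the only other measured member, compound 1 `CN1CCC(COc2ccc3c(Nc4ccc(NC(=O)Nc5ccc(Cl)c(C(F)(F)F)c5)cc4)ncnc3c2)CC1`, gives 92 nM. Compound 3 `CN1CCC(COc2ccc3c(Nc4ccc(NC(=O)Nc5ccc(Br)cc5F)cc4)ncnc3c2)CC1` is still unmeasured and differs from compound 2 as follows: 4-bromo-2-fluorophenyl in place of ethyl on an amide-type nitrogen. In words, 4-bromo-2-fluorophenyl stands in place of ethyl on an amide-type nitrogen, with the rest of the structure unchanged.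

Among the compounds with values here, one measured step bears on this change: a 6.4-fold higher number from compound 1 to compound 2 (0.80 log units; beyond the scatter), with ethyl in place of 4-chloro-3-(trifluoromethyl)phenyl at the same place. This step lies beyond the scatter. The change to compound 3 runs the opposite way, from ethyl back to a substituted phenyl, so a lower number is expected in this assay. Within the data shown here, the support is thin, as no measured compound carries 4-bromo-2-fluorophenyl and a single step sets the size. A step somewhat smaller than the measured one is therefore assumed. The expected step is a 4.5-fold lower number from compound 2 to compound 3 (0.65 log units; beyond the scatter). For compound 3 the estimated value is 130 nM, with an expected range of 45 nM to 380 nM.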

Compound 3, half-maximal inhibitory concentration: 233 nM
The estimate for compound 3 lay 1.8-fold (0.25 log units) below the measured number, and the stated range covers the measured number.
By their numbers in this assay, from the lowest: compound 1; then compound 3; then compound 2.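

In this assay, a second substituted phenyl on the amide-type nitrogen also gives a lower number than ethyl, with a 2.5-fold lower number from compound 2 to compound 3 (0.40 log units; beyond the scatter) beyond the scatter, so the direction no longer rests on the 4-chloro-3-(trifluoromethyl)phenyl group of compound 1 alone. The choice of phenyl also counts: 4-bromo-2-fluorophenyl in place of 4-chloro-3-(trifluoromethyl)phenyl gives a 2.5-fold higher number from compound 1 to compound 3 (0.40 log units; beyond the scatter) and places compound 3 between the other two, so the gain over ethyl differs between these two phenyl groups. No measurement at hand gives a reason for either step.

The two phenyl groups differ in their halogens and in where these sit, and in the trifluoromethyl group, so the compounds shown cannot assign the gap to any one substituent; an unsubstituted phenyl or a phenyl carrying a single halogen would help to separate them. Also open, going by these compounds, is whether a saturated ring such as cyclohexyl, or a longer chain such as butyl, on the amide-type nitrogen would read like ethyl or like the substituted phenyls.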